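Cytotoxicity limits across three analogues and one prediction

A few compounds are considered here, and "the series" means these few. Any claim that something is new, unique, unknown or untested is made for them only; others in the source may bear on it.

Compound 1 `CCC(CC)O[C@@H]1C=C(C(=O)O)C[C@H](NCc2ccc(OC)cc2)[C@H]1NC(C)=O`: in an ADME assay on cells (Fibroblast, Gallus gallus) for cytotoxicity, read by CCK-8 assay, with a stated time of 48 h (a higher number here means that more compound is tolerated, a lower number that less compound is tolerated), compound 1 gives > 200000 nM, which is a limit of the assay and not a number.
Compound 2 `CCC(CC)O[C@@H]1C=C(C(=O)O)C[C@H](NCc2cccc(OC)c2)[C@H]1NC(C)=O`: in this assay compound 2 gives > 200000 nM, again a limit.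
Compound 3 `CCC(CC)Oc1ccc(CN[C@H]2CC(C(=O)O)=C[C@@H](OC(CC)CC)[C@@H]2NC(C)=O)cc1`: in this assay compound 3 gives > 200000 nM, again a limit.

Compound 2 differs from compound 1 by 3-methoxyphenyl in place of 4-methoxyphenyl on a saturated chain carbon bound to an amine nitrogen. The step that the two limits leave unreadable from compound 1 to compound 2 cannot be sized. Compound 3 differs from compound 1 by pentan-3-yl in place of methyl on an oxygen on an aromatic ring, and the step that the two limits leave unreadable from compound 1 to compound 3 is likewise unreadable. All three measured values sit at the limit of > 200000 nM in this assay, at which 3 of the 3 values shown sit.

Compound 4 `CCC(CC)Oc1cccc(CN[C@H]2CC(C(=O)O)=C[C@@H](OC(CC)CC)[C@@H]2NC(C)=O)c1` has not yet been measured. It differs from compound 2 by pentan-3-yl in place of methyl on an oxygen on an aromatic ring, the same change already made from compound 1 to compound 3, at a place described in the same words. The cores of the two pairs differ as told by 3-methoxyphenyl in place of 4-methoxyphenyl on a saturated chain carbon bound to an amine nitrogen.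

The step from compound 2 to compound 4 is expected to be a step that the limit leaves unreadable from compound 2 to compound 4, since compound 1 and compound 3 both sit at the limit of > 200000 nM in this assay, at which 3 of the 3 values shown sit. Compound 4 is therefore estimated at 300000 nM, most likely reported only as a limit, between 150000 nM and 1000000 nM.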

Compound 4, half-maximal cytotoxic concentration: > 200000 nM
Compound 4: only a limit was reported (the forecaster's own chance of this, stated with the estimate: 85%); the middle value lies beyond the limit too.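

Compound 2 and compound 4 are both reported only as limits, so the change from methoxy to (pentan-3-yl)oxy cannot be sized and no new step can be read: the limit of > 200000 nM in this assay, at which 4 of the 4 values shown sit.

The four compounds shown leave open whether their tolerated concentrations in this assay differ at all, and how far either change shifts them.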